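Chain-end variation in a three-compound series: the carboxy analogue

The source may hold more compounds than are shown below. What is called first, only, known or untested is meant among the compounds shown, and "the series" means these compounds.

Measured so far:
compound 1 `CCCn1nc(-c2cccnc2)c2ccccc2c1=O` — 86%
compound 2 `CCCCCCCCn1nc(-c2cccnc2)c2ccccc2c1=O` — 99%
compound 3 `O=c1c2ccccc2c(-c2cccnc2)nn1CCCCSc1ncccn1` — 96%

In an assay on isolated protein (Oryctolagus cuniculus) with Thromboxane-A synthase (Homo sapiens) as the target, tested at 1 uM (a lower number here means less inhibition, a higher number more inhibition at the concentration tested (going by the name of the read-out)), compound 3 stands second highest of the three numbers; its nearest neighbour is given by a number 3 percentage points lower from compound 2 to compound 3 (within the scatter) and its furthest by a number 10 percentage points higher from compound 1 to compound 3 (within the scatter). Compound 4 `O=C(O)CCCn1nc(-c2cccnc2)c2ccccc2c1=O` is not yet measured. It differs from compound 3 by carboxy in place of ((pyrimidin-2-yl)sulfanyl)methyl on a saturated chain carbon, three bonds along the chain from an aromatic nitrogen. For the measured compounds named here, two measured steps touch the same chain carbon: a number 10 percentage points higher from compound 1 to compound 3 (within the scatter) and a number 13 percentage points higher from compound 1 to compound 2 (beyond the scatter). Going by the values given here, both additions there gave numbers the same or modestly higher, but no measured step involves carboxy, so the present change is without a direct precedent. Compound 4 is therefore expected to fall somewhat lower: a number 14 percentage points lower from compound 3 to compound 4 (beyond the scatter). The estimate for compound 4 is 82%, with a range from 60% to 96%.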

Compound 4, a percentage reported as inhibition, at one concentration (the size of the read-out at that concentration, not a potency): 73%
For compound 4 the middle estimate is 9 percentage points above the measured one; the range from low to high includes it.
By their numbers in this assay, from the lowest: compound 4; then compounds 1, 3 and 2 (each within the scatter of the next, the first and the last beyond it).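

Carboxy on this saturated chain carbon is the first change there to lower the number in this assay, with a number 13 percentage points lower from compound 1 to compound 4 (beyond the scatter). Against the two longer chain ends, the change reads a number 23 percentage points lower from compound 3 to compound 4 (beyond the scatter) and a number 26 percentage points lower from compound 2 to compound 4 (beyond the scatter). Nothing at hand bears on what lies behind this drop. Still open, going by these compounds, is whether a primary amide, methyl ester or amine on the same carbon would give a similar number. Also open, on these data alone, is how a longer chain ending in a carboxylic acid would read.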